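Nitrogen substituent swap: cyanoethyl to benzyl

A few compounds are considered here, and "the series" means these few. Any claim that something is new, unique, unknown or untested is made for them only; others in the source may bear on it.

Measured so far in a functional assay on U-937/GTB cells (Homo sapiens) for cytotoxicity; a higher number here means a weaker inhibitor, a lower number a stronger inhibitor
- compound 1 `CO/N=c1\[nH]cnc2c1[n+](C/C=C(\C)CC/C=C(\C)CC/C=C(\C)CCC=C(C)C)cn2C(C)C` gives 1100 nM
- compound 2 `C=CCn1c[n+](C/C=C(\C)CC/C=C(\C)CC/C=C(\C)CCC=C(C)C)c2/c(=N/OC)[nH]cnc21` gives 1390 nM
- compound 3 `CO/N=c1\[nH]cnc2c1[n+](C/C=C(\C)CC/C=C(\C)CC/C=C(\C)CCC=C(C)C)cn2CCC#N` gives 3330 nM

Compound 3 has the highest number of the three in this assay and is the weakest inhibitor of this small set. Compound 4 `CO/N=c1\[nH]cnc2c1[n+](C/C=C(\C)CC/C=C(\C)CC/C=C(\C)CCC=C(C)C)cn2Cc1ccccc1` is not yet measured. The change is phenyl in place of cyanomethyl on a saturated chain carbon bound to an aromatic nitrogen and reads phenyl in place of cyanomethyl on a saturated chain carbon bound to an aromatic nitrogen, or 2-cyanoethyl to benzyl.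

Going by the values given here, three measured steps bear on it. Compound 1 and compound 2 lack the nitrile and stay together, with a 1.3-fold higher number from compound 1 to compound 2 (0.10 log units; within the scatter) as the step between them. Compound 3 alone carries a nitrile, and the steps to it are modest: a 3.0-fold higher number from compound 1 to compound 3 (0.48 log units; beyond the scatter) and a 2.4-fold higher number from compound 2 to compound 3 (0.38 log units; beyond the scatter) on the same scale. Among the compounds with values here, no measured compound carries a benzyl group, so this is a weak guide. A modest move back towards a lower number is expected, and the expected step is a 2.0-fold lower number from compound 3 to compound 4 (0.29 log units; within the scatter) in size. For compound 4 the estimate is 1700 nM as the expected value, with an expected range from 800 nM to 3500 nM for the measurement.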

Compound 4, half-maximal inhibitory concentration: 1070 nM
Compound 4: the middle estimate sits 1.6-fold (0.20 log units) above what was measured, and the stated range covers the measured number.
By their numbers in this assay, from the lowest: compounds 4, 1 and 2 (each within the scatter of the next); then compound 3.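

In this assay the swap of 2-cyanoethyl for benzyl gives a 3.1-fold lower number from compound 3 to compound 4 (0.49 log units; beyond the scatter), so an aromatic ring carried on the saturated chain carbon bound to the aromatic nitrogen does not share the higher number of compound 3. Benzyl falls in with the nitrile-free groups, with a 1.0-fold lower number from compound 1 to compound 4 (0.01 log units; within the scatter) against isopropyl and a 1.3-fold lower number from compound 2 to compound 4 (0.11 log units; within the scatter) against allyl, both within the scatter, so compound 1, compound 2 and compound 4 cannot be ordered and compound 3 alone stands apart. No measured evidence on these compounds accounts for that separation.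

From the compounds shown here alone, whether the nitrile itself sets compound 3 apart stays open, and a plain butyl chain or a 2-hydroxyethyl group on the same nitrogen would bear on that. Substituents on the phenyl ring, such as methoxy or a carboxylic acid, and a longer link such as 2-phenylethyl are equally open.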